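The compounds below may be only part of what the source reports. "The series", "measured", "known", "first", "only" and "open" are said of these compounds alone.

Measured compounds, values from a toxicity assay on MT4 cells (Homo sapiens) for cytotoxicity, read by MTT assay, with a stated time of 5 days; on this read-out higher numbers stand for lower toxicity in this test and lower numbers for higher toxicity in this test:

compound 1 `Cc1cc(-c2ccnc3ccccc23)cc(C)c1Nc1ccnc(Nc2ccc(C#N)cc2)n1` — 3500 nM
compound 2 `Cc1cc(-c2ccc3cc[nH]c3c2)cc(C)c1Nc1ccnc(Nc2ccc(C#N)cc2)n1` — 5800 nM

On the two numbers shown, compound 2 stands at the top, but only by a 1.7-fold higher number from compound 1 to compound 2 (0.22 log units; within the scatter); the one measured step in the series therefore changes nothing beyond the scatter.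

Compound 3 `Cc1cc(-c2cc(C)c(Nc3ccnc(Nc4ccc(C#N)cc4)n3)c(C)c2)ccn1` is not yet measured in this assay. It differs from compound 2 as follows: 2-methylpyridin-4-yl in place of 1H-indol-6-yl on an aromatic carbon.

Within the data shown here, no measured step addresses this particular exchange. Among the measured compounds shown here, the single step available, a 1.7-fold higher number from compound 1 to compound 2 (0.22 log units; within the scatter), swapped one fused bicyclic aromatic group for another at the same aromatic carbon and stayed within the scatter. The move to compound 3 replaces the 1H-indol-6-yl group with the smaller 2-methylpyridin-4-yl group at that same position; nothing in the data indicates that the group at this position moves the number outside the scatter. The expectation for compound 3 is therefore a step of a 1.2-fold lower number from compound 2 to compound 3 (0.06 log units; within the scatter), that is, no change beyond the scatter, in either direction.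

Compound 3 is estimated at 5000 nM in this assay, with a range from 2000 nM to 12000 nM.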

Compound 3, half-maximal cytotoxic concentration: 4900 nM
Compound 3: middle estimate off by 1.0-fold (0.01 log units), on the high side, and the stated range covers the measured number.
By their numbers in this assay, from the lowest: compounds 1, 3 and 2 (each within the scatter of the next).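

In this assay, the exchange of 1H-indol-6-yl for 2-methylpyridin-4-yl gives a 1.2-fold lower number from compound 2 to compound 3 (0.07 log units; within the scatter), and the exchange of quinolin-4-yl for the same group gives a 1.4-fold higher number from compound 1 to compound 3 (0.15 log units; within the scatter), so neither step moves the number beyond the scatter. Among these compounds, the earlier pair covered only two fused bicyclic groups, whereas compound 3 carries a single six-membered aromatic ring with 7 heavy atoms at this position, para to a large group, and it has 0 hydrogen-bond donors and 1 hydrogen-bond acceptor in that group, against 9 heavy atoms, 1 donor and 0 acceptors for the 1H-indol-6-yl group of compound 2; across these three aromatic groups, this read-out therefore does not separate the compounds, and the change in ring count, size and donor count leaves no step beyond the scatter. Nothing available explains why the three numbers stay so close.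

Still open, on these data alone, is whether a non-aromatic group at this position, such as a carboxylic acid, a morpholine or a longer alkyl chain, would give a step beyond the scatter. Also open, as far as these compounds go, is whether the same insensitivity would hold if the nitrile of the shared core were replaced by a primary amide.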